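This account rests on a few compounds, and the source may have more. Where it says the series, first, only, none or still open, it means among the compounds named here.

Measured so far:
compound 1 `O=C1CC(c2c(-c3ccc[nH]3)[nH]c3ccccc23)C(=O)N1` gives 8000 nM
compound 2 `Cc1ccc2[nH]c(-n3cccn3)c(C3=C(Br)C(=O)NC3=O)c2c1` gives 27000 nM
compound 3 `O=C1NC(=O)C(c2c(-n3cccn3)[nH]c3ccccc23)=C1Br` gives 24000 nM

These values come from a functional assay on LoVo cells (Homo sapiens) for cytotoxicity, read by MTT assay, with a stated time of 72 h; on this read-out lower numbers stand for stronger inhibition and higher numbers for weaker inhibition. Compound 1 has the lowest of the three numbers; compound 3 stands nearest to it, and compound 2 furthest. Compound 1 and compound 3 are built on different cores, and the difference between the two cores is not broken down here.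

Compound 2 and compound 3 differ in one place only, (methyl in place of hydrogen on an aromatic carbon). That change gave a 1.1-fold higher number from compound 3 to compound 2 (0.05 log units; within the scatter).

The unmeasured compound 4 `Cc1ccc2[nH]c(-c3ccc[nH]3)c(C3CC(=O)NC3=O)c2c1` comes from compound 1 by the same change, (methyl in place of hydrogen on an aromatic carbon). Going by the values given here, since the one earlier example of this change in this assay moved the number only within the scatter, from compound 3 to compound 2, the number for compound 4 is expected to stay close to the number for compound 1, with an estimated step of a 1.1-fold higher number from compound 1 to compound 4 (0.05 log units; within the scatter). The estimate for compound 4 in this assay is therefore 9000 nM, expected to fall between 4000 nM and 20000 nM.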

Compound 4, half-maximal inhibitory concentration: 4000 nM
Compound 4: middle estimate off by 2.3-fold (0.35 log units), on the high side, and the stated range covers the measured number.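

In this assay, placing a methyl group on this aromatic carbon of the core of compound 1 gave a 2.0-fold lower number from compound 1 to compound 4 (0.30 log units; within the scatter). Set beside the earlier example on a different core, the change looks the same on both cores as far as these numbers can tell: the same change on two cores in this assay, a 1.1-fold higher number (0.05 log units; within the scatter) from compound 3 to compound 2 and a 2.0-fold lower number (0.30 log units; within the scatter) from compound 1 to compound 4, 2.3-fold (0.35 log units) apart, within the scatter of two such steps. This shows only that, in these two pairs, the methyl-for-hydrogen swap carried over without a step that stands out from the scatter; it does not show that the change would behave the same way on every core in this series, and it does not explain how the swap acts on the cells.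

Methyl is the only group shown at this place besides hydrogen, so what a chlorine atom, a methoxy group or an amine would do there remains open. Also open, on these data alone, is whether a longer chain, such as ethyl, would stay within the scatter on either core.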